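A few compounds are considered here, and "the series" means these few. Any claim that something is new, unique, unknown or untested is made for them only; others in the source may bear on it.

Measured so far:
- Compound 1 `COc1ccc(S(=O)(=O)c2cc3cnc(Nc4ccc5[nH]ccc5c4)nc3n(C)c2=O)cc1` gives 300 nM
- Compound 2 `Cn1c(=O)c(S(=O)(=O)Nc2ccc(F)cc2)cc2cnc(Nc3ccc4[nH]ccc4c3)nc21` gives 5000 nM

Both numbers come from a functional assay on K562 cells (Homo sapiens) for inhibition, read by trypan blue exclusion, with a stated time of 72 h (on this read-out lower numbers stand for stronger inhibition and higher numbers for weaker inhibition), and compound 2, at 5000 nM on this read-out, holds the higher of the two. Going by the values given here, the one measured step that bears on what follows is a 17-fold higher number from compound 1 to compound 2 (1.22 log units; beyond the scatter) and it is large, with (4-fluorophenyl)amino in place of 4-methoxyphenyl on a sulfonyl sulfur.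

Compound 3 `Cc1ccc(S(=O)(=O)c2cc3cnc(Nc4ccc5[nH]ccc5c4)nc3n(C)c2=O)cc1` changes that same place again: 4-methylphenyl in place of (4-fluorophenyl)amino on a sulfonyl sulfur. Compound 3 thus carries 4-methylphenyl where compound 1 has 4-methoxyphenyl. Among the compounds with values here, no measured step compares those two groups, so the range must stay wide. A large step towards a lower number is therefore expected in this assay and it should roughly reverse the earlier one, with compound 1 at 300 nM as the guide. The expected size is a 17-fold lower number from compound 2 to compound 3 (1.22 log units; beyond the scatter) as estimated here. For compound 3 the estimate is 300 nM with an expected range from 100 nM to 900 nM as its limits.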

Compound 3, half-maximal inhibitory concentration: 750 nM
Estimate against measurement, compound 3: 2.5-fold (0.40 log units) below; the measured number falls inside the stated range.
By their numbers in this assay, from the lowest: compound 1; then compound 3; then compound 2.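

In this assay, the step of a 6.7-fold lower number from compound 2 to compound 3 (0.82 log units; beyond the scatter) shows that the lower number of compound 1 is not unique to the 4-methoxyphenyl group, since a second aryl group attached directly to the sulfonyl sulfur also gives a much lower number than (4-fluorophenyl)amino does. The recovery is only partial, and the group on the aromatic carbon matters at this position: methyl in place of methoxy gives a 2.5-fold higher number from compound 1 to compound 3 (0.40 log units; beyond the scatter), a modest step but one beyond the scatter, so the two sulfones remain distinct and compound 1 keeps the lowest number of the three. Nothing measured here accounts for either step.

Because the step from compound 2 to compound 3 removes the amino nitrogen and exchanges fluorine for methyl at once, these compounds cannot separate the two changes, and (4-methylphenyl)amino or 4-fluorophenyl on the same sulfonyl sulfur would be needed to do so. From the compounds shown here alone, it also remains open whether the trend from methyl to methoxy extends to an ethoxy group, a hydroxyl or a dimethylamino group on that aromatic carbon.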